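Swapping Chloro for Methyl on a Shared Core

A few compounds are considered here, and "the series" means these few. Any claim that something is new, unique, unknown or untested is made for them only; others in the source may bear on it.

Compound 1, `Cc1cccc(-c2nn(-c3ccccc3)cc2C(Nc2nc3ccccc3s2)c2c(O)ccc3ccccc23)c1`: 17300 nM
Compound 2, `Oc1ccc2ccccc2c1C(Nc1nc2ccccc2s1)c1cn(-c2ccccc2)nc1-c1cccc(Cl)c1`: 20700 nM
Compound 3, `O=[N+]([O-])c1ccc(-c2nn(-c3ccccc3)cc2C(Nc2nc3ccc(Cl)cc3s2)c2c(O)ccc3ccccc23)cc1`: 38600 nM

These three compounds share one core and were tested in a functional assay on MCF7 cells (Homo sapiens) for antiproliferative activity, read by MTT assay, with a stated time of 48 h; on this read-out lower numbers stand for stronger inhibition and higher numbers for weaker inhibition. Compound 2 and compound 1 differ by methyl in place of chloro on an aromatic carbon, and the step is a 1.2-fold lower number from compound 2 to compound 1 (0.08 log units; within the scatter). Compound 3 differs from compound 2 in more than one place; the difference between the two cores is not broken down here. Compound 3 gives a higher number than compound 1, while compound 3 and compound 2 lie within the scatter of each other.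

Compound 4, `Cc1ccc2nc(NC(c3cn(-c4ccccc4)nc3-c3ccc([N+](=O)[O-])cc3)c3c(O)ccc4ccccc34)sc2c1`, is not yet measured. It differs from compound 3 by methyl in place of chloro on an aromatic carbon. This is the same kind of change as from compound 2 to compound 1, but its place differs: there the ring was a six-membered aromatic ring of carbon only, meta to a large group; here the ring is part of a fused or bridged system of two rings, meta to a fused ring and para to a fused ring. A similarly small step is expected, a 1.2-fold lower number from compound 3 to compound 4 (0.08 log units; within the scatter), because the earlier step was a 1.2-fold lower number from compound 2 to compound 1 (0.08 log units; within the scatter). Compound 4 is therefore estimated at 32000 nM in this assay, with a range from 15000 nM to 70000 nM.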

Compound 4, half-maximal inhibitory concentration: 20700 nM
Beside the measured number, compound 4's estimate is 1.5-fold (0.19 log units) above it, and the stated range covers the measured number.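

In this assay, putting methyl in place of chloro on the benzothiazole ring gives a 1.9-fold lower number from compound 3 to compound 4 (0.27 log units; within the scatter). Set beside the same swap on the other core, the two steps agree: the same change on two cores in this assay, a 1.2-fold lower number (0.08 log units; within the scatter) from compound 2 to compound 1 and a 1.9-fold lower number (0.27 log units; within the scatter) from compound 3 to compound 4, 1.6-fold (0.19 log units) apart, within the scatter of two such steps. Across these two pairs, then, the swap carries over with the same result, a step within the scatter, but two pairs at two different places cannot show that it would do so on every core in the series, and neither step shows a real effect of the swap itself.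

Going by these compounds, it remains open how a carboxylic acid or a longer chain such as propyl would read in place of the methyl of the 6-methyl-1,3-benzothiazol-2-yl group. On these data alone, whether the swap would give a similar result in other cell lines also remains open.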